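Acylurea thiazole hydrazones: swapping the benzoyl group

A few compounds are considered here, and "the series" means these few. Any claim that something is new, unique, unknown or untested is made for them only; others in the source may bear on it.

Two compounds of the series carry measurements in a functional assay on MCF7 cells (Homo sapiens) for inhibition, read by MTT assay, with a stated time of 72 h; a lower number here means a stronger inhibitor, a higher number a weaker inhibitor. Compound 2 `CN(C(=O)NC(=O)c1cccc(C(F)(F)F)c1)c1nc(C(F)(F)F)c(C(=O)N/N=C/c2ccccc2C(F)(F)F)s1` gives 7.69 ug/mL in this assay. Compound 1 `CN(C(=O)NC(=O)c1ccc(Cl)cc1Cl)c1nc(C(F)(F)F)c(C(=O)N/N=C/c2ccc(C(F)(F)F)cc2)s1` gives 8.42 ug/mL in this assay, and the two values lie within the usual scatter of each other, so no order can be read from them. Among the measured compounds shown here, no pair of measured compounds differs in a single place, so no single measured step is available as a guide.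

Compound 3 `CN(C(=O)NC(=O)c1ccc(Cl)cc1Cl)c1nc(C(F)(F)F)c(C(=O)N/N=C/c2ccccc2C(F)(F)F)s1` is not yet measured. It differs from compound 2 in one place: 2,4-dichlorophenyl in place of 3-(trifluoromethyl)phenyl on a carbonyl carbon. The same benzoyl group, 2,4-dichlorophenyl on a carbonyl carbon, is already present in compound 1, whose value in this assay sits close to that of compound 2; the remaining part of compound 3 is that of compound 2. With both reference points within the scatter of one another, no step beyond the scatter is expected in either direction. The step from compound 2 to compound 3 in this assay is estimated at a 1.0-fold higher number from compound 2 to compound 3 (0.02 log units; within the scatter). Compound 3 is accordingly expected to give about 8 ug/mL in this assay, in the range 4.5 ug/mL to 14 ug/mL.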

Compound 3, half-maximal inhibitory concentration: 9.12 ug/mL
Compound 3: middle estimate off by 1.1-fold (0.06 log units), on the low side, within the range that was stated.
By their numbers in this assay, from the lowest: compounds 2, 1 and 3 (each within the scatter of the next).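

In this assay, the series now has its first single-place steps. Putting 2,4-dichlorophenyl in place of 3-(trifluoromethyl)phenyl on a carbonyl carbon whose other neighbour is an amide-type nitrogen gives a 1.2-fold higher number from compound 2 to compound 3 (0.07 log units; within the scatter), so at this position, with the rest of compound 2 held constant, the exchange of these two aryl groups leaves no readable difference. The second step, 2-(trifluoromethyl)phenyl in place of 4-(trifluoromethyl)phenyl on a carbon with a double bond to nitrogen, gives a 1.1-fold higher number from compound 1 to compound 3 (0.03 log units; within the scatter), so this change is also unreadable against the scatter, and with the dichlorobenzoyl group held constant neither of the two trifluoromethylphenyl groups can be ranked over the other. No measured property is available to bear on either result.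

The compounds shown carry only chlorine and trifluoromethyl on these two aromatic rings, so it remains open whether an amine, a carboxylic acid or a plain phenyl at either place would give a step beyond the scatter. Also open, as far as these compounds go, is whether these two changes would stay within the scatter on a different part of the shared core.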